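Swapping nitro for methyl on compound 3

The source may report more compounds than this note shows. Statements on the series, on what has been measured and on what is new or still open speak of the compounds shown alone.

For the measured compounds named here, in a physicochemical assay for solubility, in phosphate buffer, at pH 7.4 (on this read-out lower numbers stand for lower solubility and higher numbers for higher solubility), compound 3 `CCOC(=O)c1c(-c2cccc([N+](=O)[O-])c2)[nH]c2cccc(OC)c2c1=O` gives 49000 nM and holds the only true number so far. Compound 1 `CCOC(=O)c1c(-c2ccccc2C)[nH]c2cccc(OC)c2c1=O` gives > 100000 nM as a limit of the assay, not a number. Compound 2 `CCOC(=O)c1c(-c2cccc(C(F)(F)F)c2)[nH]c2cccc(OC)c2c1=O` gives > 100000 nM as the same kind of limit. The next structure is compound 4 `CCOC(=O)c1c(-c2cccc(C)c2)[nH]c2cccc(OC)c2c1=O` with methyl in place of nitro on an aromatic carbon. Going by the values given here, two measured steps bear on this: an at least 2.0-fold lower number from compound 2 to compound 3 (0.30 log units; that floor lies within the scatter) and an at least 2.0-fold lower number from compound 1 to compound 3 (0.30 log units; that floor lies within the scatter) and both rest on the limit of > 100000 nM in this assay, at which 2 of the 3 values shown sit, so their true sizes stay open. Read in reverse, they lead to expecting a modest rise in this assay but no firm step beyond the scatter. The expected change is a 1.6-fold higher number from compound 3 to compound 4 (0.21 log units; within the scatter) as a rough estimate. For compound 4 the estimated value is 80000 nM with a range of 35000 nM to 150000 nM and a limit instead of a number is also possible.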

Compound 4, solubility: > 100000 nM
Compound 4 was reported as a limit; the forecaster's own chance of this, stated with the estimate: 45%; middle value at least 1.2-fold (0.09 log units) away from the limit.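

In this assay compound 4 gives > 100000 nM, which is a limit of the assay and not a number. Methyl in place of nitro gives an at least 2.0-fold higher number from compound 3 to compound 4 (0.30 log units; that floor lies within the scatter), so methyl joins trifluoromethyl at this place, and only the nitro of compound 3 yields a true number there. The steps from compound 1 and compound 2 to compound 4 cannot be read because both ends are limits: the limit of > 100000 nM in this assay, at which 3 of the 4 values shown sit.

On these data alone, how far methyl and trifluoromethyl really lie from nitro stays open. Also open, as far as these compounds go, is whether an amine or a carboxylic acid at this place would give a true number.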